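The source may report more compounds than this note shows. Statements on the series, on what has been measured and on what is new or still open speak of the compounds shown alone.

Measured compounds:
Compound 1, `COc1ccc(-c2cc3ccccc3nc2/C=C/C(=O)c2ccc(F)cc2)cc1`, gives in a functional assay on H184B5F5/M10 cells (Homo sapiens) for antiproliferative activity, read by XTT assay, with a stated time of 72 h (on this read-out lower numbers stand for stronger inhibition and higher numbers for weaker inhibition), only a limit, > 10000 nM.
Compound 2, `COc1ccc(-c2cc3ccccc3nc2/C=C/C(=O)c2ccc(O)cc2)cc1`, gives in this assay 5690 nM.
Compound 3, `COc1ccc(-c2cc3ccccc3nc2/C=C/C(=O)c2cccs2)cc1`, gives in this assay 7030 nM.

Compound 3 holds the highest of the two numbers available, and the nearest to it is compound 2, with a 1.2-fold higher number from compound 2 to compound 3 (0.09 log units; within the scatter). Compound 1 reports a limit, as the limit of > 10000 nM in this assay, at which 1 of the 3 values shown sits, records, so its step to compound 3 is known only as a floor: an at least 1.4-fold lower number from compound 1 to compound 3 (0.15 log units; that floor lies within the scatter).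

Compound 4, `COc1ccc(-c2cc3ccccc3nc2/C=C/C(=O)c2cnc(N)nc2C)cc1`, differs from compound 3 in the group on the carbonyl carbon: 2-amino-4-methylpyrimidin-5-yl in place of thiophen-2-yl on a carbonyl carbon. The measured steps that touch the same place are an at least 1.4-fold lower number from compound 1 to compound 3 (0.15 log units; that floor lies within the scatter) and a 1.2-fold higher number from compound 2 to compound 3 (0.09 log units; within the scatter); the first is a floor, the second lies within the scatter. Neither involves a group like the entering one, so no step beyond the scatter in this assay is expected in either direction, and the estimate for compound 4 is 6000 nM, between 2500 nM and 15000 nM, meaning an expected 1.2-fold lower number from compound 3 to compound 4 (0.07 log units; within the scatter).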

Compound 4, half-maximal inhibitory concentration: > 10000 nM
Compound 4: no number, only a limit (the forecaster's own chance of this, stated with the estimate: 25%); middle value at least 1.6-fold (0.22 log units) away from the limit.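

In this assay compound 4 gives only a limit, > 10000 nM. Placing 2-amino-4-methylpyrimidin-5-yl, the only group shown here with nitrogen in its ring, on the carbonyl carbon gives an at least 1.4-fold higher number from compound 3 to compound 4 (0.15 log units; that floor lies within the scatter) and an at least 1.7-fold higher number from compound 2 to compound 4 (0.24 log units; that floor lies within the scatter), so neither comparison establishes a change beyond the scatter. This position now carries two quite different groups, 4-fluorophenyl in compound 1 and 2-amino-4-methylpyrimidin-5-yl in compound 4, that both end at the same limit: the limit of > 10000 nM in this assay, at which 2 of the 4 values shown sit.

From the compounds shown here alone, the step between compound 1 and compound 4 cannot be read, and how far compound 4 truly lies from compound 2 and compound 3 stays unknown. Going by these compounds, it also remains open whether a plain pyridin-3-yl, or a phenyl ring bearing an amine or a carboxylic acid, would give a number clearly separated from those of compound 2 and compound 3.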